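A methyl to ethyl step at a cytotoxicity limit

This account rests on a few compounds, and the source may have more. Where it says the series, first, only, none or still open, it means among the compounds named here.

- Compound 1 `CCCSc1nc(C(C)c2c(F)cccc2Cl)c(C)c(=O)[nH]1`, a limit only: > 1500 nM
- Compound 2 `CCC(C)Sc1nc(C(C)c2c(F)cccc2Cl)c(C)c(=O)[nH]1`, a limit only: > 1500 nM
- Compound 3 `CCC(C)Sc1nc(C(CC)c2c(F)cccc2Cl)c(C)c(=O)[nH]1`, not yet measured

In an ADME assay on MT4 cells (Homo sapiens) for activation, read by MTT assay (on this read-out lower numbers stand for higher toxicity in this test and higher numbers for lower toxicity in this test), compound 2 stands at > 1500 nM, which is a limit and not a number. Compound 1 gives > 1500 nM in this assay, also a limit. Neither compound therefore has a number yet (the limit of > 1500 nM in this assay, at which 2 of the 2 values shown sit). Compound 3 differs from compound 2 by methyl in place of hydrogen on a saturated chain carbon, two bonds along the chain from two aromatic carbons, which also reads as methyl to ethyl. Among the compounds with values here, the one measured step that bears on this is a step that the two limits leave unreadable from compound 1 to compound 2, also a methyl in place of hydrogen, but its size cannot be read. It points in no direction, and no step beyond the scatter is expected in this assay. The estimated step is a step that the limit leaves unreadable from compound 2 to compound 3. For compound 3 the expected value is 2000 nM, with an expected range from 1000 nM to 10000 nM.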

Compound 3, half-maximal cytotoxic concentration: > 3000 nM
Compound 3 ended at the assay's limit; the forecaster's own chance of this, stated with the estimate: 75%; middle value at least 1.5-fold (0.17 log units) away from the limit.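

Compound 2 and compound 3 each carry only a limit in this assay, not a number, so the step between them cannot be read. The compounds shown leave open where their true cytotoxic concentrations lie, and whether methyl to ethyl changes them at all.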